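The compounds below may be only part of what the source reports. "The series", "measured", "known", "first", "only" and "open" are said of these compounds alone.

Compound 2 `Cc1ccc(NS(=O)(=O)c2ccc(F)cc2)c([N+](=O)[O-])c1` is the only one of the three measured compounds that gives a plain number in a functional assay on PC-3 cells (Homo sapiens) for cytotoxicity, read by MTT assay, with a stated time of 5 days; a higher number here means a weaker inhibitor of growth, a lower number a stronger inhibitor of growth; in this assay compound 2 gives 850 nM. Compound 3 `Cc1ccc(-c2nnn[nH]2)c(NS(=O)(=O)c2ccc(F)cc2)c1` is reported only as a limit of this assay, > 100000 nM. For compound 1 `Cc1ccc(/N=C/c2ccccc2)cc1` the entry in this assay reads "not determined" (no result reported). Compound 4 `Cc1ccc(S(=O)(=O)Nc2ccc(C)cc2[N+](=O)[O-])cc1` has not yet been tested. It differs from compound 2 in one place: methyl in place of fluoro on an aromatic carbon, the change sitting on the six-membered aromatic ring of carbon only, para to a large group. Going by the values given here, no pair of measured compounds shows what such a swap does here, so the step from compound 2 to compound 4 is expected to stay within the usual scatter, in either direction, as a 1.1-fold higher number from compound 2 to compound 4 (0.02 log units; within the scatter). Compound 4 is then estimated at 900 nM in this assay, most likely between 300 nM and 3000 nM.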

Compound 4, concentration for 50% growth inhibition: 43700 nM
Estimate against measurement, compound 4: 49-fold (1.69 log units) below, and the stated range ends below it.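

In this assay, the swap of 4-fluorophenyl to 4-methylphenyl is far from neutral, giving a 51-fold higher number from compound 2 to compound 4 (1.71 log units; beyond the scatter). This position, para to a large group, therefore responds strongly to a small swap, although neither group carries a ring, a charge, or a hydrogen-bond donor or acceptor. Compound 4 still gives a plain number, and only compound 3 is reported as a limit: the limit of > 100000 nM in this assay, at which 1 of the 4 values shown sits.

One step cannot separate the loss of fluoro from the arrival of methyl. On these data alone, whether chloro, methoxy or an amine at this place would track compound 2 or compound 4 remains open.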